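Half-life notes: cyclohexyl to 3-bromophenyl on the shared core

The source may hold more compounds than are shown below. What is called first, only, known or untested is meant among the compounds shown, and "the series" means these compounds.

Compound 1 `O=C(NCC1CCCCC1)N1C(=O)c2ccccc2S1(=O)=O` was run in a physicochemical assay for pharmacokinetics; a lower number here means that the compound disappears faster, a higher number that the compound lasts longer. There compound 1 gives > 166 h, which is a limit of the assay and not a number. Compound 2 `O=C(NCc1ccccc1C(F)(F)F)N1C(=O)c2ccccc2S1(=O)=O` also gives only a limit, > 166 h. Compound 3 `O=C(CCc1ccccc1)N1C(=O)c2ccccc2S1(=O)=O` gives > 5.77 h, again a limit. Compound 1 thus sits at the limit of > 166 h in this assay, at which 2 of the 3 values shown sit, together with compound 2, whereas compound 3 sits at the limit of > 5.77 h in this assay, at which 1 of the 3 values shown sits. Within the data shown here, no pair of measured compounds differs in one place only, so no measured step exists.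

Compound 4 `O=C(NCc1cccc(Br)c1)N1C(=O)c2ccccc2S1(=O)=O` differs from compound 1 by 3-bromophenyl in place of cyclohexyl on a saturated chain carbon bound to an amide-type nitrogen. Compound 2 likewise carries an aromatic ring on a saturated chain carbon bound to an amide-type nitrogen and reaches its limit in this assay. The step of a number no higher from compound 1 to compound 4 (the limit leaves the size open) is therefore expected to stay within the scatter. Compound 4 is estimated at 166 h, with a range from 60 h to 500 h, and is expected to be reported only as a limit.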

Compound 4, half-life: > 166 h
Compound 4 ended at the assay's limit (the forecaster's own chance of this, stated with the estimate: 80%); the middle value sits exactly at the limit.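

Compound 1 and compound 4 both give only a limit in this assay, so the step between them cannot be read: the limit of > 166 h in this assay, at which 3 of the 4 values shown sit.

The compounds shown leave open whether 3-bromophenyl in place of cyclohexyl changes the half-life at all.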